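The compounds below may be only part of what the source reports. "The series", "measured", "known", "first", "only" and "open" are said of these compounds alone.

The three measured compounds share one core, and differ only in the aromatic group attached to it. Compound 1 `O=C(CCCCCCc1ccccc1)c1ncc(-c2ccc([N+](=O)[O-])cc2)o1` carries a 4-nitrophenyl group; in an assay (Rattus norvegicus) for inhibition of Fatty-acid amide hydrolase 1 (Homo sapiens) (a higher number here means a weaker inhibitor, a lower number a stronger inhibitor), compound 1 gives 50 nM. Compound 2 `N#Cc1ccc(-c2cnc(C(=O)CCCCCCc3ccccc3)o2)cc1` carries a nitrile in place of the nitro group, and in this assay compound 2 gives 40 nM, so the step of a 1.3-fold lower number from compound 1 to compound 2 (0.10 log units; within the scatter). Compound 3 `O=C(CCCCCCc1ccccc1)c1ncc(-c2ncccc2C(=O)O)o1` carries a 3-carboxypyridin-2-yl group instead. For compound 3, this assay reports only a limit, > 50 nM, not a fixed number. Compound 3 therefore sits at the limit of > 50 nM in this assay, at which 1 of the 3 values shown sits, the edge of what this assay resolved. The two steps leading to it read a number no lower from compound 1 to compound 3 (the limit leaves the size open) and an at least 1.2-fold higher number from compound 2 to compound 3 (0.09 log units; that floor lies within the scatter).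

Compound 4 `NC(=O)c1ccc(-c2cnc(C(=O)CCCCCCc3ccccc3)o2)nc1` has not been measured; it differs from compound 3 by 5-carbamoylpyridin-2-yl in place of 3-carboxypyridin-2-yl on an aromatic carbon. The steps from compound 1 and compound 2 to compound 3 both point toward a higher number at the acid, and only their floor is known. Compound 4 is estimated to fall nearer the neutral-substituent compounds, at 60 nM with a range of 20 nM to 300 nM, which means an expected step that the limit leaves unreadable from compound 3 to compound 4.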

Compound 4, inhibition constant: 1.2 nM
Estimate against measurement, compound 4: 50-fold (1.70 log units) above, and the stated range ends above it.
By their numbers in this assay, from the lowest: compound 4; then compounds 2 and 1 (each within the scatter of the next).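

At this position, next to the ring oxygen, replacing nitro with nitrile gave no change beyond the scatter, so the position might have seemed insensitive to its substituent, but 5-carbamoylpyridin-2-yl shows otherwise, with a 33-fold lower number from compound 2 to compound 4 (1.52 log units; beyond the scatter) and with a 42-fold lower number from compound 1 to compound 4 (1.62 log units; beyond the scatter). Two pyridine-bearing groups with the same heavy-atom count also part widely, with an at least 41-fold lower number from compound 3 to compound 4 (1.61 log units; beyond the scatter). That size is only a floor, as compound 3 carries a limit rather than a number: the limit of > 50 nM in this assay, at which 1 of the 4 values shown sits.

Going by these compounds, compound 4 differs from compound 1 and compound 2 in both its ring and its substituent, so the share of each in the gain remains open. A 4-carbamoylphenyl group or a 5-carboxypyridin-2-yl group at this position would help separate the ring, the carbamoyl group and the place of the substituent.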